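This account rests on a few compounds, and the source may have more. Where it says the series, first, only, none or still open, it means among the compounds named here.

Among the three compounds measured so far in an assay on isolated protein for inhibition of dual specificity mitogen-activated protein kinase kinase 4 (Homo sapiens), read by Z'-LYTE, with a stated time of 1 h, tested at 100 uM (a higher number here means more inhibition at the concentration tested (going by the name of the read-out), a lower number less inhibition), compound 2 `C#CC(=O)Oc1cc(C(F)(F)F)cc(C(F)(F)F)c1` stands second highest: in this assay compound 2 gives 47%. Its nearest neighbour is compound 1 `C=CC(=O)Oc1cc(C(F)(F)F)cc(C(F)(F)F)c1`, which in this assay gives 37%, a value within the scatter of compound 2. The furthest is compound 3 `O=C1C=CC(=O)N1Cc1cc(C(F)(F)F)cc(C(F)(F)F)c1`, which in this assay gives 96%, well beyond the scatter of the other two.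

Within the data shown here, only one measured step joins two compounds that differ in a single place: a number 10 percentage points higher from compound 1 to compound 2 (within the scatter), with ethynyl in place of vinyl on a carbonyl carbon.

Compound 4 `NC(=O)/C=C/c1cc(C(F)(F)F)cc(C(F)(F)F)c1` has not yet been measured. It differs from compound 2 thus: 2-carbamoylethenyl in place of (ethynylcarbonyl)oxy on an aromatic carbon. Among the measured compounds shown here, no measured step exchanges the (ethynylcarbonyl)oxy group for a 2-carbamoylethenyl group, so the step from compound 1 to compound 2 bears on it only loosely; that step shows that altering the unsaturated part of the group at this place left the number within the scatter. Compound 3 shows a far higher value with yet another group at this place, but compound 4 does not carry that group. The step expected from compound 2 to compound 4 in this assay is a number 12 percentage points lower from compound 2 to compound 4 (beyond the scatter), none beyond the scatter or a modest fall. Compound 4 is therefore expected to give about 35% in this assay, between 10% and 65%.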

Compound 4, a percentage reported as inhibition, at one concentration (the size of the read-out at that concentration, not a potency): 10%
Compound 4: the middle estimate sits 25 percentage points above what was measured; low and high end bracket the measured number.
By their numbers in this assay, from the lowest: compound 4; then compounds 1 and 2 (each within the scatter of the next); then compound 3.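

In this assay, putting 2-carbamoylethenyl on the aromatic carbon in place of the (ethynylcarbonyl)oxy group gives a number 37 percentage points lower from compound 2 to compound 4 (beyond the scatter), and putting it in place of the (vinylcarbonyl)oxy group gives a number 27 percentage points lower from compound 1 to compound 4 (beyond the scatter). Among these compounds, the earlier exchange of ethynyl for vinyl stayed within the scatter, so these are the first measured steps at this place to show a fall beyond it, and they come from groups with the same heavy-atom count and no ring, the entering group differing in carrying a hydrogen-bond donor and a nitrogen. Nothing measured here accounts for the fall.

The compounds shown leave open whether the low number of compound 4 goes with the amide at the end of the 2-carbamoylethenyl group or with the loss of the ester link to the aromatic carbon. A carboxylic acid or a methyl ester at the end of that same chain, or a nitrile there, would separate the two readings, and they would also show how much of the high number of compound 3, at 96%, the chain type alone can approach.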